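Anilide series: para substituent swap on the anilino ring

The source may hold more compounds than are shown below. What is called first, only, known or untested is meant among the compounds shown, and "the series" means these compounds.

Three compounds share one core and differ only in the substituted phenyl on the amino nitrogen. In a functional assay on MGC-803 cells (Homo sapiens) for inhibition, read by MTT assay, with a stated time of 72 h (a higher number here means a weaker inhibitor, a lower number a stronger inhibitor), compound 1 `C=CC(=O)Nc1cccc(NC(=O)CSc2nc(Nc3cccc(Cl)c3)c3ccccc3n2)c1` gives 7830 nM, compound 2 `C=CC(=O)Nc1cccc(NC(=O)CSc2nc(Nc3ccc(F)cc3)c3ccccc3n2)c1` gives 8290 nM, and compound 3 `C=CC(=O)Nc1cccc(NC(=O)CSc2nc(Nc3ccc(C(F)(F)F)cc3)c3ccccc3n2)c1` gives 12100 nM. Compound 3 has the highest number of the three, but the step of a 1.5-fold higher number from compound 2 to compound 3 (0.16 log units; within the scatter) and the step of a 1.5-fold higher number from compound 1 to compound 3 (0.19 log units; within the scatter) are both within the scatter; the step of a 1.1-fold higher number from compound 1 to compound 2 (0.02 log units; within the scatter) is likewise within the scatter. On the numbers shown, the three compounds are indistinguishable.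

Compound 4 `C=CC(=O)Nc1cccc(NC(=O)CSc2nc(Nc3ccc(CC)cc3)c3ccccc3n2)c1` is the untested member. It differs from compound 3 in one place: ethyl in place of trifluoromethyl on an aromatic carbon. Within the data shown here, no measured step swaps trifluoromethyl for ethyl, so the only guide is that every substituent change on this phenyl ring so far, whether fluoro, chloro or trifluoromethyl, has left this assay within the scatter. A step of no more than the scatter is therefore expected for compound 4 in this assay, with no direction preferred; the expected step is a 1.2-fold lower number from compound 3 to compound 4 (0.08 log units; within the scatter). Compound 4 is estimated at 10000 nM, with a range of 5000 nM to 20000 nM.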

Compound 4, half-maximal inhibitory concentration: 8010 nM
Beside the measured number, compound 4's estimate is 1.2-fold (0.10 log units) above it; the range from low to high includes it.
By their numbers in this assay, from the lowest: compounds 1, 4, 2 and 3 (each within the scatter of the next).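

In this assay, the step to ethyl on the aromatic carbon para to a large group is a 1.5-fold lower number from compound 3 to compound 4 (0.18 log units; within the scatter) and adds a carbon-only group to the fluoro, chloro and trifluoromethyl groups already seen on this phenyl ring, while the substituent goes from 4 heavy atoms to 2. The comparisons with the other two compounds are just as flat, with a 1.0-fold lower number from compound 2 to compound 4 (0.01 log units; within the scatter) for ethyl in place of fluoro and a 1.0-fold higher number from compound 1 to compound 4 (0.01 log units; within the scatter) for 4-ethylphenyl in place of 3-chlorophenyl, so all four compounds remain indistinguishable and no substituent shown here separates from the others, with none going against this flat pattern. Nothing available bears on the reason for this flatness.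

Still open, going by these compounds, is whether a group of another kind on this aromatic carbon, such as an amine, a carboxylic acid or a longer alkyl chain, would give a step beyond the scatter. Also open, on these data alone, is whether changes elsewhere on the shared core, rather than on this phenyl ring, would move the number in a way that this set cannot show.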